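A Fourth Group on the Amide Nitrogen

This account rests on a few compounds, and the source may have more. Where it says the series, first, only, none or still open, it means among the compounds named here.

Compound 1 `COc1cccc(NC(=O)COc2ccc3cc(/C=C4/SC(=O)NC4=O)ccc3c2)c1` was tested in an assay on isolated protein for inhibition of histone deacetylase 8 (Homo sapiens), with a stated time of 1 h (on this read-out lower numbers stand for stronger inhibition and higher numbers for weaker inhibition), where compound 1 gives 7600 nM. Compound 2 `O=C(COc1ccc2cc(/C=C3/SC(=O)NC3=O)ccc2c1)Nc1cccc(F)n1` gives 7200 nM in this assay, and compound 3 `Cc1cccc2sc(NC(=O)COc3ccc4cc(/C=C5/SC(=O)NC5=O)ccc4c3)nc12` gives 5800 nM. Of the three numbers, that of compound 1 is the highest, yet the steps of a 1.1-fold lower number from compound 1 to compound 2 (0.02 log units; within the scatter) and a 1.3-fold lower number from compound 1 to compound 3 (0.12 log units; within the scatter) both lie within the scatter, as does the step of a 1.2-fold lower number from compound 2 to compound 3 (0.09 log units; within the scatter). Compound 4 `Cc1cc(NC(=O)COc2ccc3cc(/C=C4/SC(=O)NC4=O)ccc3c2)no1` has not yet been measured. It differs from compound 1 in one place: 5-methyl-1,2-oxazol-3-yl in place of 3-methoxyphenyl on an amide-type nitrogen. The measured steps that bear on this are the two other exchanges of the group on the amide-type nitrogen, from compound 1 to compound 2 and from compound 1 to compound 3, each within the scatter. For a third exchange of the same group, no step beyond the scatter is therefore expected in this assay. Compound 4 is estimated at 7000 nM, with a range from 3500 nM to 14000 nM. The step this estimate means, a 1.1-fold lower number from compound 1 to compound 4 (0.04 log units; within the scatter), is expected to stay within the scatter.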

Compound 4, half-maximal inhibitory concentration: > 50000 nM
Compound 4 gave a limit, no number (the forecaster's own chance of this, stated with the estimate: 5%); middle value at least 7.1-fold (0.85 log units) away from the limit.
By their numbers in this assay, from the lowest: compounds 3, 2 and 1 (each within the scatter of the next). At a limit, above all of these: compound 4.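

In this assay compound 4 gives only a limit of the assay, not a number: the limit of > 50000 nM in this assay, at which 1 of the 4 values shown sits.

Within the data shown here, the group on the amide-type nitrogen therefore matters in a way the earlier compounds did not show: the 5-methyl-1,2-oxazol-3-yl group brings an at least 6.5-fold higher number from compound 1 to compound 4 (0.81 log units; beyond the scatter) and an at least 6.9-fold higher number from compound 2 to compound 4 (0.84 log units; beyond the scatter) and also an at least 8.6-fold higher number from compound 3 to compound 4 (0.93 log units; beyond the scatter) as its steps. The 3-methoxyphenyl, 6-fluoropyridin-2-yl and 4-methyl-1,3-benzothiazol-2-yl groups stay within the scatter of one another, so this position accepts those three alike but not this five-membered aromatic ring with 2 hetero atoms.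

As far as these compounds go, the true size of these steps stays open, and this single exchange cannot tell whether the loss belongs to the five-membered ring or to its methyl group. An unsubstituted 1,2-oxazol-3-yl group, a 1,3-thiazol-2-yl group or a plain phenyl group on the same nitrogen would bear on that question.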